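The compounds below may be only part of what the source reports. "The series", "measured", "known", "first", "only" and "open" are said of these compounds alone.

In an in vitro assay on 293-EBNA cells for binding affinity to corticotropin-releasing factor receptor 1 (Homo sapiens) (on this read-out higher numbers stand for weaker inhibition and lower numbers for stronger inhibition), the measured compounds are:

Compound 1 `Cc1nc(N2CCCCC2)c2nnn(-c3ccc(C(C)C)cc3Br)c2n1` gives 46 nM
Compound 2 `CCC(COC)N(C)c1nc(C)nc2c1nnn2-c1ccc(C(C)C)cc1Br` gives 11.2 nM
Compound 3 `CCCCN(CC)c1nc(C)nc2c1nnn2-c1c(C)cc(C)nc1C` gives 65 nM

Compound 2 has the lowest number of the three, and its gaps to compound 1 and to compound 3 both lie beyond the scatter, so it is the strongest binder here. Compound 4 `Cc1nc(N2CCCC2)c2nnn(-c3ccc(C(C)C)cc3Br)c2n1` differs from compound 2 by a group of 5 heavy atoms (4 carbon, 1 nitrogen; one five-membered non-aromatic ring with 1 hetero atom) in place of a group of 8 heavy atoms (6 carbon, 1 nitrogen, 1 oxygen; no ring), on an aromatic carbon. Going by the values given here, the one measured step that bears on this change is a 4.1-fold lower number from compound 1 to compound 2 (0.61 log units; beyond the scatter), where a six-membered ring amine gave way to the open chain. Putting a ring amine back, now five-membered, is expected to undo part of that gain, giving a 3.6-fold higher number from compound 2 to compound 4 (0.55 log units; beyond the scatter). Compound 4 is therefore estimated at 40 nM, with a range from 15 nM to 110 nM.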

Compound 4, inhibition constant: 194 nM
The estimate for compound 4 lay 4.9-fold (0.69 log units) below the measured number; measured number outside the range, above it.
By their numbers in this assay, from the lowest: compound 2; then compounds 1 and 3 (each within the scatter of the next); then compound 4.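

The size of the ring amine at this position matters: pyrrolidin-1-yl in place of piperidin-1-yl gives a 4.2-fold higher number from compound 1 to compound 4 (0.63 log units; beyond the scatter) and lies beyond the scatter. The open chain now stands further from the smaller ring than from the larger one, with a 17-fold higher number from compound 2 to compound 4 (1.24 log units; beyond the scatter) as the largest step in the set. Nothing measured here gives a reason for either step.

Going by these compounds, whether a larger ring such as azepan-1-yl, or a morpholine ring, would lower the number further remains open. So does the role of the oxygen in the open chain of compound 2, which an all-carbon chain could test.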